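From fluoro to amino on a chlorinated core

A few compounds are considered here, and "the series" means these few. Any claim that something is new, unique, unknown or untested is made for them only; others in the source may bear on it.

Values measured in an ADME assay on L1210/0 cells (Mus musculus) for cytotoxicity, with a stated time of 48 h (on this read-out higher numbers stand for weaker inhibition and lower numbers for stronger inhibition), are these
- Compound 1 `OC[C@@H]1C[C@H](Cn2cnc3c(Cl)ncnc32)c2c(-c3ccccc3)nnc(-c3ccccc3)c21` reads > 200000 nM as a limit
- Compound 2 `CC(=O)OC(C)Cn1cnc2c(Cl)nc(F)nc21` reads 37000 nM as a number
- Compound 3 `CC(=O)OCCOCn1cnc2c(Cl)ncnc21` reads 163000 nM as a number

Compound 1 gives only a limit and no number. Of the two true numbers, compound 2 has the lower, and compound 3 lies nearest at 163000 nM with a gap beyond the scatter. The account now turns to compound 4 `CC(=O)OC(C)Cn1cnc2c(Cl)nc(N)nc21` which is compound 2 with amino in place of fluoro on an aromatic carbon between two ring nitrogen atoms and meta to a chloro group. Among the measured compounds shown here, no measured pair here shows this change, so the expectation is only loosely founded. Because compound 2 at 37000 nM has the lowest number shown, a move toward weaker inhibition seems more likely than a move toward stronger. The expected change is a 2.4-fold higher number from compound 2 to compound 4 (0.39 log units; beyond the scatter) in this assay and this moderate estimated rise would lie just beyond the scatter. For compound 4 the estimate is 90000 nM with an expected range from 35000 nM to 200000 nM on this read-out.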

Compound 4, half-maximal inhibitory concentration: > 200000 nM
Compound 4 was reported as a limit; the forecaster's own chance of this, stated with the estimate: 25%; middle value at least 2.2-fold (0.34 log units) from the limit.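

In this assay compound 4 gives > 200000 nM, which is a limit and not a number. Among the compounds shown here, this is the first step in the set between compounds that differ in one place: amino in place of fluoro on an aromatic carbon, between two ring nitrogen atoms and meta to a chloro group, gives an at least 5.4-fold higher number from compound 2 to compound 4 (0.73 log units; beyond the scatter), so the group on this carbon clearly matters to the read-out. The step sets only a floor on the size of the change, and the reading of compound 4 ends where that of compound 1 does: the limit of > 200000 nM in this assay, at which 2 of the 4 values shown sit.

On these data alone, how much higher the true number of compound 4 lies remains open. So does whether a methoxy group or a methylamino group on this same carbon would stay close to compound 2 or go the way of amino.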